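From a butyl to a propargyl chain

The source may report more compounds than this note shows. Statements on the series, on what has been measured and on what is new or still open speak of the compounds shown alone.

Compound 1 `CCCOc1ccc([C@@H]2CC(=O)c3cc(CC=C(C)C)c(OC)cc3O2)cc1` gives 54%
Compound 2 `COc1cc2c(cc1CC=C(C)C)C(=O)C[C@@H](c1ccc(Oc3cccc([N+](=O)[O-])c3)cc1)O2` gives 21%
Compound 3 `CCCCOc1ccc([C@@H]2CC(=O)c3cc(CC=C(C)C)c(OC)cc3O2)cc1` gives 48%

All three values come from a functional assay on PC-3 cells (Homo sapiens) for inhibition, read by sulforhodamine B assay, with a stated time of 48 h, tested at 50 uM (on this read-out higher numbers stand for more inhibition of growth at the one concentration tested and lower numbers for less inhibition of growth), and all three compounds share one core. Two steps place compound 3: a number 6 percentage points lower from compound 1 to compound 3 (within the scatter) on one side and a number 27 percentage points higher from compound 2 to compound 3 (beyond the scatter) on the other.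

The change to compound 4 `C#CCOc1ccc([C@@H]2CC(=O)c3cc(CC=C(C)C)c(OC)cc3O2)cc1` is ethynyl in place of propyl on a saturated chain carbon bound to an oxygen on an aromatic ring and nothing else. The closest measured chain change is a number 6 percentage points lower from compound 1 to compound 3 (within the scatter) and it stays small. The one large move is a number 33 percentage points lower from compound 1 to compound 2 (beyond the scatter) and it put a ring where a chain stood, which compound 4 does not do. Within the data shown here, no measured compound holds a triple bond, so the expectation remains uncertain.

A step within the scatter is therefore expected in this assay with no clear direction. The expected size is a number 2 percentage points higher from compound 3 to compound 4 (within the scatter) on this estimate. Compound 4 is expected at about 50% with an estimated range of 35% to 65% around that value.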

Compound 4, percent growth inhibition at one concentration: 52%
For compound 4 the middle estimate is 2 percentage points below the measured one; low and high end bracket the measured number.
By their numbers in this assay, from the lowest: compound 2; then compounds 3, 4 and 1 (each within the scatter of the next).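

The triple bond is new at this position, and in this assay it leaves the read-out where the saturated chains put it: the change from butyl to propargyl gives a number 4 percentage points higher from compound 3 to compound 4 (within the scatter) and the comparison with the propyl chain gives a number 2 percentage points lower from compound 1 to compound 4 (within the scatter) as the second small step. The 3-nitrophenyl group stays the exception, with a number 31 percentage points higher from compound 2 to compound 4 (beyond the scatter) on replacing it by propargyl. The butyl, propyl and propargyl chains therefore read alike, while the ring-bearing group stands apart.

From the compounds shown here alone, whether an amine, a carboxylic acid or a chain longer than butyl on that oxygen would keep this level of growth inhibition stays open, as does how these compounds compare at other concentrations. Nothing on hand gives a reason for these results.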